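Bromo for fluoro on the fused ring of compound 3

The source may hold more compounds than are shown below. What is called first, only, known or untested is meant among the compounds shown, and "the series" means these compounds.

Three members of this series carry a number in an assay on isolated protein for inhibition of Amine oxidase [flavin-containing] B (Homo sapiens), read by fluorescence, with a stated time of 15 min; on this read-out lower numbers stand for stronger inhibition and higher numbers for weaker inhibition. Compound 1 `COc1ccc(/C=C/c2cc(OC)cc(OC)c2/C=C/C(=O)c2cc3cc(OC)ccc3oc2=O)cc1` reaches only the limit of the assay, > 60000 nM, as noted in the limit of > 60000 nM in this assay, at which 1 of the 3 values shown sits. Compound 2 `COc1ccc(/C=C/c2cc(OC)cc(OC)c2/C=C/C(=O)c2cc3ccc(Br)cc3oc2=O)cc1` gives 55300 nM, and compound 3 `COc1ccc(/C=C/c2cc(OC)cc(OC)c2/C=C/C(=O)c2cc3cc(F)ccc3oc2=O)cc1` gives 10200 nM. Of the two real numbers, compound 3 holds the lower one; its nearest neighbour is compound 2, and the step of a 5.4-fold lower number from compound 2 to compound 3 (0.73 log units; beyond the scatter) lies beyond the scatter. Against the limit of compound 1, the step of an at least 5.8-fold lower number from compound 1 to compound 3 (0.76 log units; beyond the scatter) also lies beyond the scatter.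

Compound 4 `COc1ccc(/C=C/c2cc(OC)cc(OC)c2/C=C/C(=O)c2cc3cc(Br)ccc3oc2=O)cc1` differs from compound 3 by bromo in place of fluoro on an aromatic carbon. Both measured steps bear on it: the fluoro of compound 3 sits lower than a methoxy at the same place and lower than a bromo elsewhere on the same fused ring, each by a modest margin. A bromo at the place of the fluoro is therefore expected to move the number upward by a modest amount, a 2.5-fold higher number from compound 3 to compound 4 (0.39 log units; beyond the scatter). Compound 4 is estimated at 25000 nM, with a range of 8000 nM to 70000 nM.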

Compound 4, half-maximal inhibitory concentration: > 60000 nM
Compound 4 gave a limit, no number; the forecaster's own chance of this, stated with the estimate: 25%; at least 2.4-fold (0.38 log units) between middle value and limit.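

In this assay, exchanging the halogen on this aromatic carbon gives an at least 5.8-fold higher number from compound 3 to compound 4 (0.76 log units; beyond the scatter), so the lower number of compound 3 does not carry over to a second halogen here. Placing the bromo here rather than where compound 2 carries it gives an at least 1.0-fold higher number from compound 2 to compound 4 (0.03 log units; that floor lies within the scatter), and that floor sets no order between the two bromo compounds. The step from compound 1 to compound 4 cannot be read, because both values are limits: the limit of > 60000 nM in this assay, at which 2 of the 4 values shown sit.

As far as these compounds go, whether chloro, hydroxyl or an amine at this aromatic carbon would give a number in this assay stays open. Also open is whether fluoro at the place that carries the bromo in compound 2 would match compound 3, so the compounds shown do not separate the effect of the group from that of its place.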